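Chloro to fluoro on a small series

The compounds below may be only part of what the source reports. "The series", "measured", "known", "first", "only" and "open" are said of these compounds alone.

Compound 1 (`O=C1NC(=S)/C(=C/c2ccc(Cl)cc2)S1`) gives 41.4% in a functional assay on NCI-H292 cells (Homo sapiens) for cytotoxicity, read by MTT assay, with a stated time of 72 h, tested at 10 ug/mL (a lower number here means less inhibition of growth, a higher number more inhibition of growth at the concentration tested), and stands level with compound 2 (`O=C1NC(=S)/C(=C/c2cc(Cl)cc(Cl)c2Cl)S1`), which gives 40.5% and cannot be told apart from it. Compound 3 (`O=C1NC(=S)/C(=C/c2cccc(Cl)c2)S1`) gives 30.9% and lies beyond the scatter below compound 1. The next compound to be tested is compound 4 (`O=C1NC(=S)/C(=C/c2ccc(F)cc2)S1`), which has no number yet. It keeps the core of compound 1 and carries fluoro in place of chloro on an aromatic carbon.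

Among the measured compounds shown here, no two measured compounds differ in one place only, and none of them carries fluoro, so no direct step guides the expectation. For the measured compounds named here, the only guide is the spread among the chlorine-bearing compounds, with compound 3 at 30.9% and compound 1 at 41.4% as the widest gap. In this assay a small step is therefore expected, slightly downward and within the scatter, though the uncertainty is wide. The estimated change is a number 5.4 percentage points lower from compound 1 to compound 4 (within the scatter) and would leave compound 4 in the same band as the others. Compound 4 is expected to give 36% (estimated range 22% to 50%).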

Compound 4, percent growth inhibition at one concentration: 38%
Compound 4: the middle estimate sits 2 percentage points below what was measured; the range from low to high includes it.
By their numbers in this assay, from the lowest: compounds 3, 4, 2 and 1 (each within the scatter of the next, the first and the last beyond it).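

In this assay, among the compounds shown here, the exchange of chloro for fluoro on an aromatic carbon, para to a group of 8 heavy atoms, gives a number 3.4 percentage points lower from compound 1 to compound 4 (within the scatter), and this is the first comparison between two compounds that differ in one place only. At this position the two halogens therefore cannot be told apart at the single concentration tested, and chloro is not needed for compound 4 to stay level with compound 1. No measurement shown offers an explanation for this result.

The compounds shown leave open whether a group of another kind at this same place, such as an amine, a carboxylic acid or a methoxy group, would stay level with these two halogens or fall clearly away from them. They also leave open whether fluoro in place of chloro would give a similarly small step on compound 3 or on compound 2, whose chlorine atoms sit elsewhere on the ring, and whether a step this small would persist across a full concentration range.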